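The compounds below may be only part of what the source reports. "The series", "measured", "known", "first", "only" and "open" are said of these compounds alone.

Series notes, amide aryl step. Three compounds carry numbers in a functional assay on MCF7 cells (Homo sapiens) for antiproliferative activity, read by MTT assay, with a stated time of 72 h; a lower number here means a stronger inhibitor, a higher number a weaker inhibitor. Compound 1 `CCNc1cc(C)c2cc(NC(=O)c3ccc(Cl)c(Cl)c3)ccc2n1` gives 48600 nM. Among the compounds with values here, compound 3 `Cc1cc(N2CCCC2)nc2ccc(NC(=O)c3ccc(Cl)c(Cl)c3)cc12` gives 26300 nM; the one measured step, a 1.8-fold lower number from compound 1 to compound 3 (0.27 log units; within the scatter), changes only the amine side of the shared core. Compound 2 `CCN1CCN(c2cc(C)c3cc(NC(=O)c4ccccc4C)ccc3n2)CC1` gives 10900 nM, the lowest of the three numbers, beyond the scatter from both compound 3 and compound 1; compound 2 differs from each of them in two places, so its two gaps cannot be assigned to either place on the numbers shown.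

Compound 4 `CCN1CCN(c2cc(C)c3cc(NC(=O)c4cccc(Br)c4)ccc3n2)CC1` is the next member. Its difference from compound 2 is 3-bromophenyl in place of 2-methylphenyl on a carbonyl carbon. Within the data shown here, no measured step touches the carbonyl-bound aryl: the only step known, between compound 1 and compound 3, sits elsewhere and was within the scatter. Among the measured compounds shown here, compound 1 and compound 3, both with a dichlorophenyl on the carbonyl, give higher numbers than compound 2, but with two differences each that is no step. The expected step of a 1.4-fold higher number from compound 2 to compound 4 (0.14 log units; within the scatter) is therefore set to none beyond the scatter, with a wide range. Compound 4 is estimated at 15000 nM, between 5000 nM and 45000 nM.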

Compound 4, half-maximal inhibitory concentration: 11600 nM
Compound 4: the middle estimate sits 1.3-fold (0.11 log units) above what was measured; measured number inside the range.
By their numbers in this assay, from the lowest: compounds 2 and 4 (each within the scatter of the next); then compounds 3 and 1 (each within the scatter of the next).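

Within the data shown here, the first measured change at the aryl on the carbonyl carbon, a 1.1-fold higher number from compound 2 to compound 4 (0.03 log units; within the scatter), shows that in this assay 3-bromophenyl and 2-methylphenyl cannot be told apart while the rest of compound 2 stays fixed. Both groups count the same heavy atoms and one carbon-only aromatic ring, so this pair tests a bromine in place of a carbon within that count, and with it a different substitution name, without a separation in the read-out. No measured property of these compounds bears on this result.

Open, from the compounds shown here alone, is whether a phenyl carrying a carboxylic acid or an amine on that carbonyl carbon would also stay within the scatter of compound 2. Also open, going by these compounds, is how the dichlorophenyl of compound 1 and compound 3 would read on the amine side of compound 2, so the gaps separating those compounds from compound 2 still cannot be assigned to one place.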